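The source may hold more compounds than are shown below. What is called first, only, known or untested is meant among the compounds shown, and "the series" means these compounds.

In an ADME assay on the whole organism (Mus musculus, strain CD-1) for pharmacokinetics, at a dose of 10 mg/kg by the oral route (on this read-out lower numbers stand for lower oral bioavailability and higher numbers for higher oral bioavailability), compound 2 `COc1cc([C@](O)(CCN(C)C)[C@@H](c2cc3cc(Br)ccc3nc2OC)c2cccc(OC)c2F)cc(OC(F)F)n1` gives 83% and stands highest of three measured compounds, beyond the scatter of the other two. Compound 1 `CCOc1cc([C@](O)(CCN(C)C)[C@@H](c2cc3cc(Br)ccc3nc2OC)c2cccc(OC)c2F)cc(OC)n1` gives 46% and compound 3 `COc1cc([C@](O)(CCN(C)C)[C@@H](c2cc3cc(Br)ccc3nc2OC)c2ccnc(OC)c2OC)cc(OC(F)F)n1` gives 50%. Compound 4 `COc1cccc([C@H](c2cc3cc(Br)ccc3nc2OC)[C@@](O)(CCN(C)C)c2cc(SC)nc(SC)c2)c1F` differs from compound 2 in one place (a group of 10 heavy atoms (7 carbon, 1 nitrogen, 2 sulfur; one six-membered aromatic ring with 1 hetero atom) in place of a group of 12 heavy atoms (7 carbon, 1 nitrogen, 2 oxygen, 2 fluorine; one six-membered aromatic ring with 1 hetero atom), on a saturated chain carbon bound to an oxygen on a saturated carbon and two saturated chain carbons). Going by the values given here, two measured steps bear on this change, and both are large. An edit inside the group that leaves gave a number 37 percentage points higher from compound 1 to compound 2 (beyond the scatter) and an edit on another group gave a number 33 percentage points lower from compound 2 to compound 3 (beyond the scatter) so single changes can move this assay strongly. Here the whole group is replaced, and compound 2 starts from the top, so a large drop is expected (a number 33 percentage points lower from compound 2 to compound 4 (beyond the scatter)). For compound 4 the estimated value is 50% (estimated range 25% to 75%).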

Compound 4, oral bioavailability: 66%
Beside the measured number, compound 4's estimate is 16 percentage points below it, within the range that was stated.
By their numbers in this assay, from the lowest: compounds 1 and 3 (each within the scatter of the next); then compound 4; then compound 2.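

In this assay, the ring group carrying two sulfur atoms gives a number 17 percentage points lower from compound 2 to compound 4 (beyond the scatter), but also a number 20 percentage points higher from compound 1 to compound 4 (beyond the scatter). So at this position, oxygen atoms in the ring's substituents are not needed for a fairly high number, though the sulfur group does not match the difluoromethyl-bearing group of compound 2. Nothing here explains why the numbers move.

The compounds shown leave open how a ring carrying one sulfur group and one difluoromethoxy group, or one carrying amine groups, would fare at this position.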